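A few compounds are considered here, and "the series" means these few. Any claim that something is new, unique, unknown or untested is made for them only; others in the source may bear on it.

Measured in a functional assay on MDA-MB-231 cells (Homo sapiens) for inhibition, read by MTT assay, with a stated time of 72 h; a lower number here means a stronger inhibitor, a higher number a weaker inhibitor:
- compound 1 `CC(C)(C)n1cc2c(n1)C(=O)CC1(CCN(C(=O)c3cc(-c4ccc(Cl)cc4)nc4ccccc34)CC1)O2`: > 10000 nM
- compound 2 `CC(C)(C)n1cc2c(n1)C(=O)CC1(CCN(C(=O)c3cc(-c4ccc(Br)cc4)nc4ccccc34)CC1)O2`: > 10000 nM
- compound 3 `COc1ccc(-c2cc(C(=O)N3CCC4(CC3)CC(=O)c3nn(C(C)(C)C)cc3O4)c3ccccc3n2)cc1`: > 10000 nM

Compound 3 stands at > 10000 nM, which is a limit and not a number. Going by the values given here, the series so far shows (the limit of > 10000 nM in this assay, at which 3 of the 3 values shown sit).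

Compound 4 `CC(C)(C)n1cc2c(n1)C(=O)CC1(CCN(C(=O)c3cc(-c4ccc(N)cc4)nc4ccccc34)CC1)O2` has amino in place of methoxy on an aromatic carbon, para to a large group: amino in place of methoxy on an aromatic carbon.

Three measured changes bear on this place: a step that the two limits leave unreadable from compound 1 to compound 2, a step that the two limits leave unreadable from compound 1 to compound 3 and a step that the two limits leave unreadable from compound 2 to compound 3. None of them gives a size, so no step beyond the scatter can be expected from them in this assay, and the same limit is the likely outcome. The expected step is a step that the limit leaves unreadable from compound 3 to compound 4. Compound 4 is estimated at 12000 nM, with an expected range from 4000 nM to 30000 nM.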

Compound 4, half-maximal inhibitory concentration: 4960 nM
The estimate for compound 4 lay 2.4-fold (0.38 log units) above the measured number; measured number inside the range.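

In this assay, going by these compounds alone, compound 4, with its 4-aminophenyl, gives 4960 nM, the only value that is a number and not a limit. Its steps read as an at least 2.0-fold lower number from compound 3 to compound 4 (0.30 log units; that floor lies within the scatter), an at least 2.0-fold lower number from compound 2 to compound 4 (0.30 log units; that floor lies within the scatter) and an at least 2.0-fold lower number from compound 1 to compound 4 (0.30 log units; that floor lies within the scatter). The steps among the other three compounds cannot be read, and each step to compound 4 is only a floor: the limit of > 10000 nM in this assay, at which 3 of the 4 values shown sit.

On these data alone, the true size of the change from methoxy, bromo or chloro to amino stays open. Also open, as far as these compounds go, is whether a hydroxyl, a dimethylamino group or an acetylated amine at this position would give a number or the same limit.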